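The source may hold more compounds than are shown below. What is called first, only, known or untested is meant among the compounds shown, and "the series" means these compounds.

In a functional assay on SW480 cells (Homo sapiens) for antiproliferative activity, read by MTT assay, with a stated time of 48 h (on this read-out higher numbers stand for weaker inhibition and lower numbers for stronger inhibition), compound 1 `CCCCCC(CCO)n1cnc2c(N(C)C)ncnc21` gives only a limit, > 50000 nM. Compound 2 `CCCCCCCC(CCO)n1cnc2c(N(C)C)ncnc21`, which carries dimethylamino, also gives only a limit, > 50000 nM. Among the compounds with values here, the single measured step is a step that the two limits leave unreadable from compound 1 to compound 2, so it offers no size to carry forward. Within the data shown here, compound 3 `CCCCCCCCC(CCO)n1cnc2c(OC)ncnc21`, at 24600 nM, is the only compound with an actual number. Compound 4 `CCCCCCCCC(CCO)n1cnc2c(N(C)C)ncnc21` differs from it in one place, with dimethylamino in place of methoxy on an aromatic carbon. Among the measured compounds shown here, no measured step makes this swap, so the evidence is thin. The expected change, a 1.3-fold higher number from compound 3 to compound 4 (0.11 log units; within the scatter), is small, towards weaker inhibition, and may not exceed the usual scatter. The estimated value for compound 4 is 32000 nM, with an expected range of 14000 nM to 70000 nM.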

Compound 4, half-maximal inhibitory concentration: 21600 nM
Compound 4: middle estimate off by 1.5-fold (0.17 log units), on the high side; the range from low to high includes it.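

In this assay the group on this aromatic carbon makes little difference on the longest chain shown: the swap gives a 1.1-fold lower number from compound 3 to compound 4 (0.06 log units; within the scatter) and leaves methoxy and dimethylamino level. With dimethylamino held fixed, chain length now has a readable effect, with an at least 2.3-fold lower number from compound 2 to compound 4 (0.36 log units; beyond the scatter) and an at least 2.3-fold lower number from compound 1 to compound 4 (0.36 log units; beyond the scatter) towards stronger inhibition. Both of these sizes start from a limit, not a number: the limit of > 50000 nM in this assay, at which 2 of the 4 values shown sit. As far as these compounds go, whether a different group on this carbon, such as a primary amine or a chlorine atom, would shift the number remains open. So does whether a longer chain would lower it further.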